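Acetyl in place of nitro: expected binding for compound 3

This account rests on a few compounds, and the source may have more. Where it says the series, first, only, none or still open, it means among the compounds named here.

Measured so far in an assay on cell membranes for binding affinity to Fatty-acid amide hydrolase 1 (Rattus norvegicus); a lower number here means a stronger inhibitor, a higher number a weaker inhibitor:
compound 1, `Cc1cccc(-c2cccc(OC(=O)NC3CCCCC3)c2)c1`, gives 61.8 nM
compound 2, `O=C(NC1CCCCC1)Oc1cccc(-c2cccc([N+](=O)[O-])c2)c1`, gives 49.6 nM

Compound 2 stands beside compound 1 in this assay: a 1.2-fold lower number from compound 1 to compound 2 (0.10 log units; within the scatter), so the two numbers are indistinguishable. Compound 3, `CC(=O)c1cccc(-c2cccc(OC(=O)NC3CCCCC3)c2)c1`, differs from compound 2 by acetyl in place of nitro on an aromatic carbon. Going by the values given here, the only measured step that bears on this position, a 1.2-fold lower number from compound 1 to compound 2 (0.10 log units; within the scatter), shows that exchanging one small group for another there left the number within the scatter. Among the compounds with values here, no measured step involves acetyl. The step from compound 2 to compound 3 in this assay is therefore expected to stay within the scatter: a 1.1-fold higher number from compound 2 to compound 3 (0.04 log units; within the scatter). Compound 3 is estimated at 55 nM, with a range of 20 nM to 150 nM.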

Compound 3, half-maximal inhibitory concentration: 9.1 nM
Compound 3: the middle estimate sits 6.0-fold (0.78 log units) above what was measured; the measured number lies below the stated range.
By their numbers in this assay, from the lowest: compound 3; then compounds 2 and 1 (each within the scatter of the next).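

In this assay this aromatic position proves sensitive to the group it carries, which the close values for methyl and nitro did not reveal: acetyl brings a 5.5-fold lower number from compound 2 to compound 3 (0.74 log units; beyond the scatter) and also a 6.8-fold lower number from compound 1 to compound 3 (0.83 log units; beyond the scatter). Of the three groups shown, only acetyl stands apart, while methyl and nitro remain within the scatter of each other. No available evidence accounts for this difference. Still open, from the compounds shown here alone, is whether the lower number is specific to acetyl or extends to a longer ketone such as propanoyl, an amide or a carboxylic acid. Going by these compounds, how acetyl behaves elsewhere on this ring also remains unknown.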